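Replacing a chain with amino on a double-bonded nitrogen

The compounds below may be only part of what the source reports. "The series", "measured", "known", "first", "only" and "open" are said of these compounds alone.

- Compound 1 `CCCCCCC/N=C(\S)C1(c2ccccn2)CCCS1`: > 30 mg/kg
- Compound 2 `CN(C)CC/N=C(\S)C1(c2ccccn2)CCCS1`: > 30 mg/kg
- Compound 3 `CN(C)CCC/N=C(\S)C1(c2ccccn2)CCCS1`: > 30 mg/kg

All three compounds were tested in a functional assay on the whole organism (stomach) with Rattus norvegicus as the target; on this read-out higher numbers stand for an effect only at larger amounts of compound and lower numbers for an effect already at smaller amounts. Compound 3 gives > 30 mg/kg, which is a limit of the assay and not a number. It shares that position with the other two compounds: the limit of > 30 mg/kg in this assay, at which 3 of the 3 values shown sit.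

The next compound, compound 4 `N/N=C(\S)C1(c2ccccn2)CCCS1`, carries amino in place of 3-(dimethylamino)propyl on a double-bonded nitrogen. The chain on this same nitrogen also differs in the three measured steps, so they are the ones that bear on the change. They are a step that the two limits leave unreadable from compound 1 to compound 2, a step that the two limits leave unreadable from compound 1 to compound 3 and a step that the two limits leave unreadable from compound 2 to compound 3. None of them has a readable size, so none offers a size or direction to carry over.

The expectation therefore follows compound 3, which reads > 30 mg/kg. Another limit reading in this assay is the likeliest result, although amino is a much smaller group than any chain tested so far, so a measurable number remains possible. The expected change is a step that the limit leaves unreadable from compound 3 to compound 4, an estimate with no firm direction. For compound 4 the estimated value is 35 mg/kg, with an expected range from 10 mg/kg to 100 mg/kg.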

Compound 4, dose for half-maximal effect: > 30 mg/kg
Compound 4: only a limit was reported; the forecaster's own chance of this, stated with the estimate: 70%; the middle value does not contradict the limit.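

In this assay compound 4 gives > 30 mg/kg, which is a limit of the assay and not a number. No step from compound 1, compound 2 or compound 3 to compound 4 can be read, as all four share one position: the limit of > 30 mg/kg in this assay, at which 4 of the 4 values shown sit.

As far as these compounds go, whether the group on the double-bonded nitrogen affects this read-out at all remains open.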